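A few compounds are considered here, and "the series" means these few. Any claim that something is new, unique, unknown or untested is made for them only; others in the source may bear on it.

Measured compounds:
compound 1 `CNC(=O)/C=C/c1ccncc1-c1ccc2ccccc2c1` — 6550 nM
compound 2 `CN1CCN(C(=O)/C=C/c2ccncc2-c2ccc(F)cc2)CC1` — "not determined" (no result reported)
compound 3 `O=C(/C=C/c1ccncc1-c1ccc2cccnc2c1)N1CCOCC1` — "not determined" (no result reported)

Among the measured compounds shown here, in a functional assay on HCT-116 cells (Homo sapiens) for inhibition, read by MTT assay, with a stated time of 72 h (on this read-out lower numbers stand for stronger inhibition of growth and higher numbers for weaker inhibition of growth), compound 1 gives 6550 nM, and it stands as the only number in the set; compound 2 and compound 3 carry no value, so no step between measured compounds can be read. Compound 4 `O=C(O)/C=C/c1ccncc1-c1ccc2ccccc2c1` differs from compound 1 in one place: hydroxy in place of methylamino on a carbonyl carbon. With a single number to go on, the expectation for this change in this assay is a loss beyond the usual scatter, though not a large one. Compound 4 is estimated at 15000 nM, with a range of 5000 nM to 50000 nM. The expected step of a 2.3-fold higher number from compound 1 to compound 4 (0.36 log units; beyond the scatter) is read as a move toward weaker inhibition of growth.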

Compound 4, concentration for 50% growth inhibition: > 30000 nM
Compound 4 was reported as a limit; the forecaster's own chance of this, stated with the estimate: 30%; middle value at least 2.0-fold (0.30 log units) from the limit.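

At the carbonyl carbon, hydroxy in place of methylamino weakens growth inhibition in this assay, with an at least 4.5-fold higher number from compound 1 to compound 4 (0.66 log units; beyond the scatter). The reading for compound 4 is a limit of the assay and not a number: the limit of > 30000 nM in this assay, at which 1 of the 4 values shown sits. This position is therefore sensitive to the change from methylcarbamoyl to carboxy, which the lone value of compound 1 could not show.

From the compounds shown here alone, it remains open how a methyl ester or a longer chain on the amide nitrogen would read at this carbonyl carbon. Going by these compounds, whether any such group would match or improve on methylamino also remains open.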